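A few compounds are considered here, and "the series" means these few. Any claim that something is new, unique, unknown or untested is made for them only; others in the source may bear on it.

In a functional assay on the whole organism for cytotoxicity, with Homo sapiens as the target (on this read-out lower numbers stand for stronger inhibition of growth and higher numbers for weaker inhibition of growth), compound 1 `CCCCCCn1c(=O)oc2ccc(NCc3cc(O)ccc3O)cc2c1=O` gives 4200 nM, while compound 2 `Oc1ccc(O)c(CNc2ccc(O)c(/C=C\CCc3ccccc3)c2)c1` gives 17800 nM. That is the higher of the two numbers, so compound 2 is the weaker growth inhibitor, by a gap beyond the usual scatter. Compound 3 `Oc1ccc(O)c(CNc2ccc(O)c(/C=C/CCc3ccccc3)c2)c1` differs from compound 2 only in configuration as drawn (the two compounds have the same atoms and bonds and differ only in configuration as drawn: 1 of 1 stereo elements differ; a double bond is drawn Z in compound 2 and E in compound 3): a double bond is drawn Z in compound 2 and E in compound 3. Within the data shown here, no measured pair shows what this swap does, so only a small change in this assay is expected, an estimated 1.3-fold lower number from compound 2 to compound 3 (0.10 log units; within the scatter), within the scatter. The estimate for compound 3 is 14000 nM, with an expected range of 5000 nM to 40000 nM.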

Compound 3, concentration for 50% growth inhibition: 21400 nM
Estimate against measurement, compound 3: 1.5-fold (0.18 log units) below, within the range that was stated.
By their numbers in this assay, from the lowest: compound 1; then compounds 2 and 3 (each within the scatter of the next).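

In this assay the swap gives a 1.2-fold higher number from compound 2 to compound 3 (0.08 log units; within the scatter), so drawing the double bond Z or E does not separate these two compounds in this read-out. This is the first pair that can be read as a single change, and it isolates one feature: the fact that compounds 2 and 3 differ only in the configuration as drawn

The compounds shown say nothing about how the double bond itself counts, since both carry it. A fully saturated chain, a shorter chain, or a chain carrying an amine or a carboxylic acid could behave quite differently at this position.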